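This account rests on a few compounds, and the source may have more. Where it says the series, first, only, none or still open, it means among the compounds named here.

Compound 1 `O=C1/C(=C/c2ccc(Br)cc2)CCc2ccccc21` was tested in a functional assay on CCRF-CEM cells (Homo sapiens) for inhibition; a lower number here means a stronger inhibitor, a higher number a weaker inhibitor. For compound 1 the result > 500000 nM is a limit of the assay rather than a number. Compound 2 `Cc1ccc(/C=C2\CCc3ccccc3C2=O)cc1` gives 460000 nM in this assay. The two compounds differ in one place (methyl in place of bromo on an aromatic carbon), and the step of an at least 1.0-fold lower number from compound 1 to compound 2 (0.03 log units; that floor lies within the scatter) is only a floor, since it rests on (the limit of > 500000 nM in this assay, at which 1 of the 3 values shown sits). Compound 3 `O=C1/C(=C/c2cccc(Br)c2)CCCc2ccccc21` is built on another core; the difference between the two cores is not broken down here. In this assay compound 3 gives 8900 nM, the lower of the two numbers measured. Compound 4 `Cc1cccc(/C=C2\CCCc3ccccc3C2=O)c1` has not yet been measured. It differs from compound 3 in one place (methyl in place of bromo on an aromatic carbon). This is the same kind of change as that from compound 1 to compound 2, but there the group sat para to a large group, while here it sits meta to a large group. Because the earlier step of an at least 1.0-fold lower number from compound 1 to compound 2 (0.03 log units; that floor lies within the scatter) shows only a floor, a small step of a 1.3-fold lower number from compound 3 to compound 4 (0.10 log units; within the scatter) is expected. Compound 4 is therefore expected to give about 7000 nM in this assay, most likely between 2500 nM and 20000 nM.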

Compound 4, half-maximal inhibitory concentration: 15800 nM
Compound 4: the middle estimate sits 2.3-fold (0.35 log units) below what was measured, within the range that was stated.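

In this assay, putting methyl in place of bromo on the core of compound 3 gives a 1.8-fold higher number from compound 3 to compound 4 (0.25 log units; within the scatter), so on this core the change has no effect that can be told apart from the usual scatter. Whether the change behaves the same way on both cores cannot be settled: the same change on two cores in this assay, an at least 1.0-fold lower number (0.03 log units; that floor lies within the scatter) from compound 1 to compound 2 and a 1.8-fold higher number (0.25 log units; within the scatter) from compound 3 to compound 4; the limit leaves it open whether they differ. Compound 1 carries a limit of the assay rather than a number, so the step on its core is only a floor, and the data show neither that the change carries over between the cores nor that it fails to: the limit of > 500000 nM in this assay, at which 1 of the 4 values shown sits.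

Only bromo and methyl appear at the changed position, which leaves open how an amine or a carboxylic acid would behave there on either core. Also open, on these data alone, is whether a pair on the core of compound 1 with true numbers for both members would match the small step seen on the core of compound 3.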